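Alpha-2B agonist series: ether-to-sulfone step at the aromatic ring

The source may hold more compounds than are shown below. What is called first, only, known or untested is meant among the compounds shown, and "the series" means these compounds.

Measured so far:
compound 1, `C=COc1ccccc1OC(C)C1=NCCN1`, a functional assay on CHO cells for agonist activity at Alpha-2B adrenergic receptor (Homo sapiens); a higher number here means that more compound is needed for the effect, a lower number that less compound is needed: 3160 nM
compound 2, `COc1ccccc1OC(C)C1=NCCN1`, this assay: 100000 nM

Compound 2 stands at the highest of the two numbers; its nearest neighbour is compound 1, and the step of a 32-fold higher number from compound 1 to compound 2 (1.50 log units; beyond the scatter) is large and beyond the scatter. Compound 3, `CC(Oc1ccccc1S(C)(=O)=O)C1=NCCN1`, differs from compound 2 by methylsulfonyl in place of methoxy on an aromatic carbon. Going by the values given here, no measured step touches the group that changes here; the single measured step from compound 1 to compound 2 concerns the substituent on the same ring oxygen, which now leaves altogether, so it bears only loosely on the new change. The data give no direct basis for direction. A step of uncertain sign is expected, a 3.3-fold lower number from compound 2 to compound 3 (0.52 log units; beyond the scatter), with a wide range. The estimate for compound 3 in this assay is 30000 nM, expected between 3000 nM and 150000 nM.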

Compound 3, half-maximal effective concentration: 10000 nM
Compound 3: the middle estimate sits 3.0-fold (0.48 log units) above what was measured, within the range that was stated.
By their numbers in this assay, from the lowest: compound 1; then compound 3; then compound 2.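

At this aromatic carbon, the atom attached to the ring need not be an ether oxygen: in this assay there is a 10-fold lower number from compound 2 to compound 3 (1.00 log units; beyond the scatter) when methylsulfonyl replaces methoxy, so the change recovers part of the ground lost with methoxy. Vinyloxy still gives the lowest number of the three, with a 3.2-fold higher number from compound 1 to compound 3 (0.50 log units; beyond the scatter) when methylsulfonyl stands in its place, so a group need not be an ether to improve on methoxy, yet methylsulfonyl does not reach vinyloxy. Nothing available explains either step.

The compounds leave open whether the lower number belongs to methylsulfonyl in particular or would also appear with other groups on this carbon, such as an amine, a carboxylic acid or a longer alkoxy chain. Going by these compounds alone, with only three compounds, the order among them describes these groups alone and gives no general trend for this position.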